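2-Phenylethenyl in place of 2-chlorophenyl on the saturated carbon

The compounds below may be only part of what the source reports. "The series", "measured", "known", "first", "only" and "open" are said of these compounds alone.

Compound 1 `Cc1cc(O)c(C2=NN(c3ccc(S(N)(=O)=O)cc3)C(c3ccccc3O)C2)cc1Cl`: 2720 nM
Compound 2 `Cc1cc(O)c(C2=NN(c3ccc(S(N)(=O)=O)cc3)C(c3ccccc3Cl)C2)cc1Cl`: 2620 nM

Of the compounds shown here, two have been tested in a functional assay on Malme-3M cells (Homo sapiens) for antiproliferative activity, with a stated time of 48 h; on this read-out higher numbers stand for weaker inhibition of growth and lower numbers for stronger inhibition of growth. Compound 1 gives 2720 nM there. Compound 2 gives 2620 nM in this assay. For the measured compounds named here, the one measured step, a 1.0-fold lower number from compound 1 to compound 2 (0.02 log units; within the scatter), lies within the scatter, so the two numbers cannot be told apart, and compound 2 stands level with compound 1 rather than apart from it.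

Compound 3 `Cc1cc(O)c(C2=NN(c3ccc(S(N)(=O)=O)cc3)C(/C=C/c3ccccc3)C2)cc1Cl` is the next compound. It differs from compound 2 by 2-phenylethenyl in place of 2-chlorophenyl on a saturated ring carbon. Going by the values given here, no measured step bears on this change: the only step known exchanges a hydroxy for a chloro on an aromatic carbon, whereas here the whole 2-chlorophenyl group gives way to a 2-phenylethenyl group carrying one double bond outside aromatic rings. Among the compounds with values here, since the single change seen so far left this assay unmoved, the expectation for compound 3 is a step of a 1.0-fold lower number from compound 2 to compound 3 (0.00 log units; within the scatter), that is none beyond the scatter, though with wide uncertainty. Compound 3 is therefore estimated at 2600 nM in this assay, within a range of 900 nM to 7500 nM.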

Compound 3, concentration for 50% growth inhibition: 3010 nM
Compound 3: middle estimate off by 1.2-fold (0.06 log units), on the low side; low and high end bracket the measured number.
By their numbers in this assay, from the lowest: compounds 2, 1 and 3 (each within the scatter of the next).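

In this assay, 2-phenylethenyl in place of 2-chlorophenyl on the saturated ring carbon gives a 1.1-fold higher number from compound 2 to compound 3 (0.06 log units; within the scatter) and, in place of 2-hydroxyphenyl at the same carbon, gives a 1.1-fold higher number from compound 1 to compound 3 (0.04 log units; within the scatter) as the second step, so neither exchange can be told from the scatter. The earlier pair showed only that a hydroxy and a chloro on the aromatic ring at this position could not be separated, whereas compound 3 shows that the whole aryl group attached to this carbon can give way to a group with a double bond outside aromatic rings and a larger count of heavy atoms, with all three compounds standing level. No independent measurement is available to account for this level result.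

From the compounds shown here alone, all three groups at this position still carry a six-membered aromatic ring of carbon only, so it remains open whether a plain alkyl chain, an amine or a carboxylic acid on this carbon would also leave the number level. The 4-sulfamoylphenyl and 5-chloro-2-hydroxy-4-methylphenyl groups are the same throughout, so the compounds shown also say nothing about exchanging the sulfamoyl group for a carboxylic acid or the ring hydroxy for a methoxy.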